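This account rests on a few compounds, and the source may have more. Where it says the series, first, only, none or still open, it means among the compounds named here.

Compound 3 `COc1ccccc1/C=C/C(=O)/C=C/C1=C(C)CCCC1(C)C` gives 13400 nM in a functional assay on MCF7 cells (Homo sapiens) for cytotoxicity, read by sulforhodamine B assay, with a stated time of 48 h (on this read-out higher numbers stand for weaker inhibition and lower numbers for stronger inhibition), and stands second highest of the three numbers measured. Compound 1 `CC1=C(/C=C/C(=O)/C=C/c2ccc(Cl)cc2)C(C)(C)CCC1`, which gives 10200 nM, lies within the scatter of compound 3; compound 2 `CC1=C(/C=C/C(=O)/C=C/c2ccccc2Cl)C(C)(C)CCC1`, which gives 54600 nM, lies beyond the scatter above compound 3. Compound 4 `CC1=C(/C=C/C(=O)/C=C/c2ccccc2Br)C(C)(C)CCC1` differs from compound 3 by bromo in place of methoxy on an aromatic carbon. The step of a 4.1-fold lower number from compound 2 to compound 3 (0.61 log units; beyond the scatter) bears on this change most directly, since it exchanged chloro for methoxy at the same aromatic carbon; the step of a 5.4-fold higher number from compound 1 to compound 2 (0.73 log units; beyond the scatter) concerns the same ring. Undoing the former exchange, with bromo now in place of chloro, a modest rise toward the number of compound 2 is expected. Compound 4 is therefore estimated at 45000 nM in this assay, with a range from 18000 nM to 110000 nM, an expected step of a 3.4-fold higher number from compound 3 to compound 4 (0.53 log units; beyond the scatter).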

Compound 4, half-maximal inhibitory concentration: 20700 nM
Estimate against measurement, compound 4: 2.2-fold (0.34 log units) above; measured number inside the range.
By their numbers in this assay, from the lowest: compounds 1, 3 and 4 (each within the scatter of the next, the first and the last beyond it); then compound 2.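

In this assay, methoxy and bromo on this aromatic carbon cannot be told apart, with a 1.5-fold higher number from compound 3 to compound 4 (0.19 log units; within the scatter) within the scatter. The change from chloro to bromo at the same carbon does register, with a 2.6-fold lower number from compound 2 to compound 4 (0.42 log units; beyond the scatter) beyond the scatter, so the high number of compound 2 is not shared by the other halogen tested there. The change to 2-bromophenyl from 4-chlorophenyl also lies beyond the scatter, with a 2.0-fold higher number from compound 1 to compound 4 (0.31 log units; beyond the scatter) as a modest step. Nothing available explains these differences. From the compounds shown here alone, whether fluoro or an amine on this aromatic carbon would group with methoxy and bromo or with chloro remains open.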